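Swapping phenyl for benzyl on a growth inhibitor

This account rests on a few compounds, and the source may have more. Where it says the series, first, only, none or still open, it means among the compounds named here.

Compound 1 `c1ccc(COc2cccc(NC3=NCCO3)c2)cc1`: 1500 nM
Compound 2 `O=C(CCl)NC(=O)Nc1cccc(Oc2ccccc2)c1`: 5300 nM

In a functional assay on M21 cells (Homo sapiens) for inhibition, read by sulforhodamine B assay, with a stated time of 48 h (on this read-out higher numbers stand for weaker inhibition of growth and lower numbers for stronger inhibition of growth), compound 2 has the higher of the two numbers, and its gap to compound 1 lies beyond the scatter. Compound 3 `O=C(CCl)NC(=O)Nc1cccc(OCc2ccccc2)c1` differs from compound 2 in one place: benzyl in place of phenyl on an oxygen on an aromatic ring. Among the measured compounds shown here, no measured pair shows this change alone. Compound 1, at 1500 nM, also carries benzyl on such an oxygen, but its core differs, so only a small move towards a lower number is expected, within the scatter. The estimated change is a 1.5-fold lower number from compound 2 to compound 3 (0.18 log units; within the scatter). For compound 3 the expected value is 3500 nM, with an estimated range of 1500 nM to 8000 nM.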

Compound 3, concentration for 50% growth inhibition: 4500 nM
For compound 3 the middle estimate is 1.3-fold (0.11 log units) below the measured one; the range from low to high includes it.
By their numbers in this assay, from the lowest: compound 1; then compounds 3 and 2 (each within the scatter of the next).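

Going from phenyl to benzyl on this oxygen in this assay gives a 1.2-fold lower number from compound 2 to compound 3 (0.07 log units; within the scatter) and so leaves the number unmoved within the scatter, even with the extra carbon atom. With benzyl on the oxygen in both compounds, replacing the five-membered non-aromatic ring on the nitrogen with the open chlorine-bearing chain gives a 3.0-fold higher number from compound 1 to compound 3 (0.48 log units; beyond the scatter) as a modest step beyond the scatter. No measurement here explains either step. From the compounds shown here alone, whether a longer chain such as phenethyl on this oxygen would change the number stays open, and so does the effect of an amine on the benzyl ring.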